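Furan to thiophene swap on a shared cyano-pyrimidinone core

A few compounds are considered here, and "the series" means these few. Any claim that something is new, unique, unknown or untested is made for them only; others in the source may bear on it.

Measured compounds:
- compound 1, `CCOC(=O)c1cnn(-c2nc(-c3ccccc3F)c(C#N)c(=O)n2C)c1N`, which in a functional assay, with a stated time of 20 min (a higher number here means a weaker inhibitor, a lower number a stronger inhibitor), gives 69 ug/mL
- compound 2, `CSc1nc(-c2ccco2)c(C#N)c(=O)n1C`, which in this assay gives 68 ug/mL
- compound 3, `CCOC(=O)c1cnn(-c2nc(-c3cccc(OC)c3OC)c(C#N)c(=O)n2C)c1N`, which in this assay gives 54 ug/mL

Compound 2 holds the second highest of the three numbers. Going by the values given here, its nearest neighbour is compound 1, whose value is within the scatter of it, and the furthest is compound 3, also within the scatter; no step between compound 2 and either of the others has been worked out, so only the closeness of their values can be read.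

The unmeasured compound 4, `CSc1nc(-c2cccs2)c(C#N)c(=O)n1C`, differs from compound 2 in one place: thiophen-2-yl in place of furan-2-yl on an aromatic carbon. Among the compounds with values here, one measured step bears on this, since it also exchanges one aromatic group for another at the same aromatic carbon of the shared core: a 1.3-fold lower number from compound 1 to compound 3 (0.11 log units; within the scatter), a change that stayed within the scatter. With that single precedent, and with a change that keeps the ring size, the hetero-atom count and the hydrogen-bond acceptor count, no step beyond the scatter is expected in this assay, so the estimated step is no change at the digits printed from compound 2 to compound 4 (within the scatter). Compound 4 is therefore expected to give about 68 ug/mL, with a likely range from 35 ug/mL to 135 ug/mL.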

Compound 4, half-maximal inhibitory concentration: 71 ug/mL
Beside the measured number, compound 4's estimate is 1.0-fold (0.02 log units) below it; measured number inside the range.
By their numbers in this assay, from the lowest: compounds 3, 2, 1 and 4 (each within the scatter of the next).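

In this assay, putting thiophen-2-yl in place of furan-2-yl on this aromatic carbon, with the rest of the molecule unchanged, gives a 1.0-fold higher number from compound 2 to compound 4 (0.02 log units; within the scatter), so the two five-membered rings, one holding oxygen and the other sulfur, cannot be told apart here. Going by these compounds alone, the earlier step at this carbon, a 1.3-fold lower number from compound 1 to compound 3 (0.11 log units; within the scatter), compared only two substituted phenyl groups on a core with a different group elsewhere, and the new step shows a second exchange within the scatter, this time between five-membered rings on the core that carries methylsulfanyl. No measurement shown gives a reason why these two rings read alike.

As far as these compounds go, it remains open whether a group of a different kind on this carbon, such as an amine, a carboxylic acid or a longer alkyl chain, would produce a step beyond the scatter. From the compounds shown here alone, it is also open whether the exchange of furan-2-yl for thiophen-2-yl would read the same way on the core of compound 1, which carries a different group in place of methylsulfanyl.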